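The source may hold more compounds than are shown below. What is called first, only, known or untested is meant among the compounds shown, and "the series" means these compounds.

Compound 1 `NS(=O)(=O)c1cc(-c2nnc(CN3CCN(c4ccccc4)CC3)o2)c(Cl)cc1SCc1ccccc1` gives 105000 nM in a functional assay on HCT-116 cells (Homo sapiens) for cytotoxicity, read by MTT assay, with a stated time of 72 h; a higher number here means a weaker inhibitor, a lower number a stronger inhibitor.
Compound 2 `NS(=O)(=O)c1cc(-c2nnc(CN3CCN(c4ccc(Cl)cc4)CC3)o2)c(Cl)cc1SCc1ccccc1` gives 78000 nM in this assay.
Compound 3 `NS(=O)(=O)c1cc(-c2nnc(/C=C/c3ccccc3)o2)c(Cl)cc1SCc1ccccc1` gives 18000 nM in this assay.

Compound 1 and compound 2 differ by one change, (chloro in place of hydrogen on an aromatic carbon), and that change made a 1.3-fold lower number from compound 1 to compound 2 (0.13 log units; within the scatter). Compound 3 has a different core; the difference between the two cores is not broken down here, but compound 3 gives the lowest number of the three measured. Compound 4 `NS(=O)(=O)c1cc(-c2nnc(/C=C/c3cccc(Cl)c3)o2)c(Cl)cc1SCc1ccccc1` is not yet measured. It differs from compound 3 by chloro in place of hydrogen on an aromatic carbon. This is the same kind of change as that from compound 1 to compound 2, but not the same: there the chloro enters para to a large group, here meta to a large group. Because the earlier step was a 1.3-fold lower number from compound 1 to compound 2 (0.13 log units; within the scatter), a comparable small step is expected here, a 1.3-fold lower number from compound 3 to compound 4 (0.11 log units; within the scatter). Compound 4 is therefore estimated at 14000 nM, between 6000 nM and 35000 nM.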

Compound 4, half-maximal inhibitory concentration: 12000 nM
For compound 4 the middle estimate is 1.2-fold (0.07 log units) above the measured one; the range from low to high includes it.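

In this assay, chloro in place of hydrogen on an aromatic carbon gives a 1.5-fold lower number from compound 3 to compound 4 (0.18 log units; within the scatter), so this pair of compounds cannot be told apart. Set beside the same change on the other core, the step looks alike on both cores: the same change on two cores in this assay, a 1.3-fold lower number (0.13 log units; within the scatter) from compound 1 to compound 2 and a 1.5-fold lower number (0.18 log units; within the scatter) from compound 3 to compound 4, 1.1-fold (0.05 log units) apart, within the scatter of two such steps. Among these compounds, this shows only that the change made no clear difference on either core; it does not show that chloro itself alters the number, or that the same would hold on a third core.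

Still open, from the compounds shown here alone, is whether another group on that ring, such as a methoxy group, an amine or a carboxylic acid, would give a step beyond the scatter.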